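Replacing a pentyl chain with tert-butylphenyl on a shared core

A few compounds are considered here, and "the series" means these few. Any claim that something is new, unique, unknown or untested is made for them only; others in the source may bear on it.

Compound 2 `CCCCCc1cc(-c2cn([C@H]3C[C@H](OC(C)=O)[C@@H](COC(C)=O)O3)c(=O)[nH]c2=O)on1` is tested in a functional assay on NCI-H23 cells (Homo sapiens) for cytotoxicity, read by sulforhodamine B assay, tested at 10 uM (a lower number here means less inhibition, a higher number more inhibition at the concentration tested (going by the name of the read-out)), and gives 88.9%. Compound 1 `CCCc1cc(-c2cn([C@H]3C[C@H](OC(C)=O)[C@@H](COC(C)=O)O3)c(=O)[nH]c2=O)on1` gives 96.9%, and compound 3 `CC(=O)OC[C@H]1O[C@@H](n2cc(-c3cn(Cc4ccc(C(C)C)cc4)nn3)c(=O)[nH]c2=O)C[C@@H]1OC(C)=O` gives 86.7%; all three values lie within the scatter of one another, so compound 2 sits among them without a distinguishable rank. Compound 4 `CC(=O)OC[C@H]1O[C@@H](n2cc(-c3cc(-c4ccc(C(C)(C)C)cc4)no3)c(=O)[nH]c2=O)C[C@@H]1OC(C)=O` is not yet measured and differs from compound 2 in one place: 4-(tert-butyl)phenyl in place of pentyl on an aromatic carbon. For the measured compounds named here, the only measured step at this position, a number 8 percentage points lower from compound 1 to compound 2 (within the scatter), lies within the scatter, and no measured step describes an aromatic group entering here. Compound 4 is therefore expected to show a step of a number 6.9 percentage points lower from compound 2 to compound 4 (within the scatter), not beyond the scatter. Compound 4 is estimated at 82%, between 50% and 98%.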

Compound 4, a percentage reported as inhibition, at one concentration (the size of the read-out at that concentration, not a potency): 112%
Compound 4: middle estimate off by 30 percentage points, on the low side, and the stated range ends below it.
By their numbers in this assay, from the lowest: compounds 3, 2 and 1 (each within the scatter of the next, the first and the last beyond it); then compound 4.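

In this assay, 4-(tert-butyl)phenyl at this aromatic carbon moves the number beyond the scatter, with a step of (a number 23.1 percentage points higher from compound 2 to compound 4 (beyond the scatter)) against pentyl and one of (a number 15.1 percentage points higher from compound 1 to compound 4 (beyond the scatter)) against propyl. The position therefore responds to the group it carries, which the step between the two chains had not shown. Nothing at hand explains the rise. Going by these compounds, whether it comes from the aromatic ring itself or from its tert-butyl group remains open. So does how a plain phenyl, a 4-methoxyphenyl or a pyridine would read here.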